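Two Chlorines for a Fluorine on the Sulfur-Linked Ring

This account rests on a few compounds, and the source may have more. Where it says the series, first, only, none or still open, it means among the compounds named here.

Three compounds sharing one core have been measured in a functional assay on NCI-H23 cells (Homo sapiens) for inhibition, read by sulforhodamine B assay, with a stated time of 48 h; a lower number here means a stronger inhibitor of growth, a higher number a weaker inhibitor of growth:

Compound 1 `CCOC(=O)[C@H](CCC(=O)O)NC(=O)c1ccc(Sc2nc3cc(N)cc(N)c3nc2-c2ccccc2)cc1`: 11700 nM
Compound 2 `Nc1cc(N)c2nc(-c3ccccc3)c(Sc3ccc(F)cc3)nc2c1`: 19100 nM
Compound 3 `COc1cc(CNc2nc3cc(N)cc(N)c3nc2-c2ccccc2)cc(OC)c1OC`: 8710 nM

Compound 2 gives the highest of these three numbers, though compound 1 sits within the usual scatter of it; only compound 3 lies clearly lower. Compound 4 `Nc1cc(N)c2nc(-c3ccccc3)c(Sc3ccc(Cl)c(Cl)c3)nc2c1` is a close relative of compound 2, differing by 3,4-dichlorophenyl in place of 4-fluorophenyl on a sulfur. Going by the values given here, no measured pair isolates this kind of swap, so nothing here shows how much it matters. The step of a 1.6-fold lower number from compound 2 to compound 4 (0.20 log units; within the scatter) is therefore expected to be modest, leaning toward a lower number but not surely beyond the scatter. For compound 4 the expected value is 12000 nM, within a range from 4000 nM to 36000 nM.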

Compound 4, concentration for 50% growth inhibition: 12600 nM
Estimate against measurement, compound 4: 1.1-fold (0.02 log units) below; low and high end bracket the measured number.
By their numbers in this assay, from the lowest: compounds 3, 1, 4 and 2 (each within the scatter of the next, the first and the last beyond it).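

In this assay, going by these compounds alone, putting 3,4-dichlorophenyl in place of 4-fluorophenyl on a sulfur gives a 1.5-fold lower number from compound 2 to compound 4 (0.18 log units; within the scatter), the first step here that isolates a single change. The two chlorines and the single fluorine therefore cannot be told apart at this position, as the two compounds stay within the usual scatter of each other. Nothing available bears on the reason for this result.

As far as these compounds go, whether an amine or a nitrile on this ring would move the number beyond the scatter remains open. So does the effect of each chlorine alone.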